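Isopropoxy to cyclopropyloxy: a small step expected

This account rests on a few compounds, and the source may have more. Where it says the series, first, only, none or still open, it means among the compounds named here.

Compound 1 `Cn1cc(-c2ccccc2Oc2ccccc2)c2cc(C(=O)NCCCCCCC(=O)NO)[nH]c2c1=O`: 180 nM
Compound 2 `CC(C)Oc1ccc(C(C)(C)O)cc1-c1cn(C)c(=O)c2[nH]c(C(=O)NCCCCCCC(=O)NO)cc12`: 160 nM

Both compounds were tested in a functional assay on MV4-11 cells (Homo sapiens) for antiproliferative activity, read by CCK-8 assay, with a stated time of 72 h (on this read-out lower numbers stand for stronger inhibition and higher numbers for weaker inhibition), and share the same core. Compound 1 at 180 nM and compound 2 at 160 nM lie within the scatter of each other, so the numbers set no order between them.

A further compound, compound 3 `Cn1cc(-c2cc(C(C)(C)O)ccc2OC2CC2)c2cc(C(=O)NCCCCCCC(=O)NO)[nH]c2c1=O`, has not yet been measured. It departs from compound 2 in one place: cyclopropyl in place of isopropyl on an oxygen on an aromatic ring. This puts cyclopropyl in place of isopropyl on an oxygen on an aromatic ring. Among the measured compounds shown here, no two measured compounds differ in one place only, so the data hold no direct measure of this change. For the measured compounds named here, the only guide is that compound 1 and compound 2 differ in more than one place and still stand within the scatter. No step beyond the scatter is therefore expected in this assay, in either direction. The estimated 1.1-fold lower number from compound 2 to compound 3 (0.03 log units; within the scatter) stays within that scatter. For compound 3 the expected value is 150 nM, with an estimated range from 60 nM to 380 nM.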

Compound 3, half-maximal inhibitory concentration: 220 nM
Compound 3: the middle estimate sits 1.5-fold (0.17 log units) below what was measured; the measured number falls inside the stated range.
By their numbers in this assay, from the lowest: compounds 2, 1 and 3 (each within the scatter of the next).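

Among the compounds shown here, the pair gives the first direct reading of a change at this place, on an oxygen on an aromatic ring: in this assay replacing isopropyl with cyclopropyl gives a 1.4-fold higher number from compound 2 to compound 3 (0.14 log units; within the scatter) and so sets no order between the two groups. Compounds 1 and 2 differ in more than one place and could not isolate this change, whereas here the two groups have the same count of heavy atoms and differ by the three-membered ring of carbon only. That ring takes the place of the open isopropyl group without a step beyond the scatter in this read-out, and no measurement in hand bears on the reason for this result.

The compounds shown leave open how far this tolerance reaches, since both groups in the pair hold three carbons: a methoxy group, a free hydroxyl, a longer chain such as butoxy, or an amine on the aromatic ring in place of the oxygen could each give a different reading. They also leave open whether the same exchange would stay this small in a compound that lacks the other substituents shared by compounds 2 and 3.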